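Moving one chlorine: what to expect for compound 4

A few compounds are considered here, and "the series" means these few. Any claim that something is new, unique, unknown or untested is made for them only; others in the source may bear on it.

- compound 1 `CC(Oc1ccc(Cl)cc1Cl)C(=O)NCc1ccccc1`: 95000 nM
- compound 2 `CC(Oc1ccc(Cl)cc1Cl)C(=O)NCc1ccccc1F`: 47000 nM
- compound 3 `CC(Oc1ccc(Cl)cc1Cl)C(=O)NCc1ccc(Cl)cc1`: 39000 nM

These numbers come from an ADME assay on CHO cells (Cricetulus griseus) for cytotoxicity, read by LDH release; a higher number here means a weaker inhibitor, a lower number a stronger inhibitor. Compound 3 stands with compound 2 at the low end of this small set. The step of a 2.4-fold lower number from compound 1 to compound 3 (0.39 log units; beyond the scatter) is modest but beyond the scatter, while the step of a 1.2-fold lower number from compound 2 to compound 3 (0.08 log units; within the scatter) lies within it.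

The next compound is compound 4 `CC(Oc1ccc(Cl)cc1Cl)C(=O)NCc1cccc(Cl)c1`. Going by the values given here, its only change is 3-chlorophenyl in place of 4-chlorophenyl on a saturated chain carbon bound to an amide-type nitrogen: 3-chlorophenyl takes the place of 4-chlorophenyl on a saturated chain carbon bound to an amide-type nitrogen.

Among the compounds with values here, no measured step moves a chlorine, so the closest guides are steps that add a group to an aromatic carbon. These are a 2.4-fold lower number from compound 1 to compound 3 (0.39 log units; beyond the scatter) and a 2.0-fold lower number from compound 1 to compound 2 (0.31 log units; beyond the scatter), both modest and in the same direction. Compound 4 keeps the chloro group and differs only in where it sits, so no shift beyond the scatter is expected. The expected result is a 1.1-fold higher number from compound 3 to compound 4 (0.03 log units; within the scatter). For compound 4 the estimated value is 42000 nM, with an expected range of 22000 nM to 80000 nM.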

Compound 4, half-maximal inhibitory concentration: 19000 nM
Beside the measured number, compound 4's estimate is 2.2-fold (0.34 log units) above it; measured number outside the range, below it.
By their numbers in this assay, from the lowest: compound 4; then compounds 3 and 2 (each within the scatter of the next); then compound 1.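

Where the chlorine sits matters in this assay: 3-chlorophenyl and 4-chlorophenyl have the same atoms, yet moving it gives a 2.1-fold lower number from compound 3 to compound 4 (0.31 log units; beyond the scatter) at this place on a saturated chain carbon bound to an amide-type nitrogen. Compound 2 and compound 3 could not be told apart, but 3-chlorophenyl separates from 2-fluorophenyl with a 2.5-fold lower number from compound 2 to compound 4 (0.39 log units; beyond the scatter) in this comparison. Against the unsubstituted phenyl, adding the chloro group gives a 5.0-fold lower number from compound 1 to compound 4 (0.70 log units; beyond the scatter) as the largest step so far, leaving compound 4 with the lowest number of the four. Nothing available explains why the position of the chlorine changes the number.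

The compounds shown leave open whether this result is special to chlorine. A methoxy group, an amine or a carboxylic acid in place of the chlorine could move the number either way.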